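The source may report more compounds than this note shows. Statements on the series, on what has been measured and on what is new or still open speak of the compounds shown alone.

Of the compounds shown here, three have so far been measured in an ADME assay (liver) for metabolic stability, with Liver microsome (Homo sapiens) as the target, read by LC-MS, using microsomes and NADPH, with a stated time of 5 min, at 37 degrees C; on this read-out lower numbers stand for slow clearance and higher numbers for fast clearance. Compound 1 `CCn1c([C@@H](C)NS(=O)(=O)c2ccc(Cl)cc2)nc2ccc(OC)cc21` gives only a limit of the assay, > 100 mL.min-1.g-1. Compound 2 `CCn1c(C(C)NS(=O)(=O)c2ccc(Cl)cc2)nc2ncccc21` gives 15 mL.min-1.g-1 in this assay. Compound 3 `CCn1c([C@@H](C)NS(=O)(=O)c2cccc(Cl)c2)nc2ccc(C(F)(F)F)cc21` also gives only a limit of the assay, > 100 mL.min-1.g-1. Going by the values given here, none of these three differ in just one place, so no measured step between them can be described; what stands out is the limit of > 100 mL.min-1.g-1 in this assay, at which 2 of the 3 values shown sit, and compound 3 is one of those two.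

Compound 4 `CCn1c([C@@H](C)NS(=O)(=O)c2cnc(NC(C)=O)s2)nc2ccc(C(F)(F)F)cc21` differs from compound 3 in one place: 2-acetamido-1,3-thiazol-5-yl in place of 3-chlorophenyl on a sulfonyl sulfur. Among the compounds with values here, with compound 3 already at the limit, the expected step of an at least 2.5-fold lower number from compound 3 to compound 4 (0.39 log units; beyond the scatter) is toward slower clearance, though its size rests on no measured pair here. Compound 4 is therefore estimated at 40 mL.min-1.g-1, with a range from 10 mL.min-1.g-1 to 100 mL.min-1.g-1.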

Compound 4, intrinsic clearance in microsomes: 15 mL.min-1.g-1
Beside the measured number, compound 4's estimate is 2.7-fold (0.43 log units) above it; low and high end bracket the measured number.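

The change on the sulfonyl sulfur gives an at least 6.6-fold lower number from compound 3 to compound 4 (0.82 log units; beyond the scatter) in this assay. With the rest of the molecule unchanged, this one group moves the read-out off the limit and into the measurable range, so the group at this position alone can decide how fast clearance appears. The full size of the step cannot be given, since compound 3 has only a limit: the limit of > 100 mL.min-1.g-1 in this assay, at which 2 of the 4 values shown sit.

From the compounds shown here alone, it remains open whether the ring or the acetamido part of the new group accounts for the step. A thiazole carrying a free amine or a methyl group in place of the acetamido group could separate the two.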